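From 3,5-dichlorobenzyl to 4-chlorobenzyl on a shared core

The compounds below may be only part of what the source reports. "The series", "measured", "known", "first", "only" and "open" are said of these compounds alone.

In a functional assay on HeLa cells (Homo sapiens) for inhibition, read by sulforhodamine B assay, with a stated time of 72 h (a lower number here means a stronger inhibitor of growth, a higher number a weaker inhibitor of growth), compound 3 (`O=C(NO)c1cnc(N2C[C@H]3CN(Cc4cc(Cl)cc(Cl)c4)C[C@H]3C2)nc1`) gives 940 nM and compound 2 (`O=C(NO)c1cnc(N2C[C@@H]3CN(S(=O)(=O)c4ccc(OC(F)(F)F)cc4)C[C@@H]3C2)nc1`) gives 940 nM while compound 1 (`O=C(NO)c1cnc(N2C[C@@H]3CN(S(=O)(=O)c4ccc5ccccc5c4)C[C@@H]3C2)nc1`) gives 1130 nM so all three lie within the usual scatter of one another. Compound 4 (`O=C(NO)c1cnc(N2C[C@H]3CN(Cc4ccc(Cl)cc4)C[C@H]3C2)nc1`) has not yet been measured. It carries 4-chlorophenyl in place of 3,5-dichlorophenyl on a saturated chain carbon bound to an amine nitrogen in a ring. Among the measured compounds shown here, no measured pair shows this kind of change on its own, so in this assay no step beyond the scatter is expected, in either direction. The estimated step of a 1.2-fold higher number from compound 3 to compound 4 (0.07 log units; within the scatter) is therefore small. For compound 4 the expected value is 1100 nM (estimated range 500 nM to 2500 nM).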

Compound 4, concentration for 50% growth inhibition: 690 nM
Compound 4: middle estimate off by 1.6-fold (0.20 log units), on the high side; the range from low to high includes it.
By their numbers in this assay, from the lowest: compounds 4, 2, 3 and 1 (each within the scatter of the next).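

Changing 3,5-dichlorobenzyl to 4-chlorobenzyl on the shared core gives a 1.4-fold lower number from compound 3 to compound 4 (0.13 log units; within the scatter) in this assay. This is the only pair shown that differs in one place, and it shows that this position accepts the change without a step beyond the scatter. Nothing measured here bears on this result.

Open, going by these compounds, is whether a plain benzyl with no chlorine would stay within the scatter of these two compounds. Also open, on these data alone, is what a more different group, such as an amine or a carboxylic acid on the phenyl ring, would do.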